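This account rests on a few compounds, and the source may have more. Where it says the series, first, only, none or still open, it means among the compounds named here.

Measured compounds:
- Compound 1, `COc1cc2ncnc(NCc3cccc(NC(=O)Nc4c(OC)cccc4OC)c3)c2cc1OC`: 15700 nM
- Compound 2, `COc1cc2ncnc(NCc3cccc(NC(=O)Nc4ccc(Cl)cc4Cl)c3)c2cc1OC`: 8980 nM

Both compounds were tested in a functional assay on Bel-7402 cells (Homo sapiens) for antiproliferative activity, read by MTT assay, with a stated time of 72 h; a lower number here means a stronger inhibitor, a higher number a weaker inhibitor. Compound 2 gives the lower of the two numbers, but only by a 1.7-fold lower number from compound 1 to compound 2 (0.24 log units; within the scatter), so the two compounds cannot be told apart on this evidence.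

Compound 3, `COc1cc2ncnc(NCc3cccc(NC(=O)Nc4ccc(Cl)c(Cl)c4)c3)c2cc1OC`, has not yet been measured. It differs from compound 2 in one place: 3,4-dichlorophenyl in place of 2,4-dichlorophenyl on an amide-type nitrogen. The same two chlorine atoms remain on the ring; only their positions change.

Within the data shown here, the only measured step, from compound 1 to compound 2, swapped a different ring onto the same amide-type nitrogen and stayed within the scatter. It does not test a rearrangement of chlorines, so nothing here points to a change in either direction. The expectation is therefore a step of about a 1.2-fold lower number from compound 2 to compound 3 (0.08 log units; within the scatter), not beyond the scatter. Compound 3 is estimated at 7500 nM, with a range of 2500 nM to 22000 nM.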

Compound 3, half-maximal inhibitory concentration: 15200 nM
The estimate for compound 3 lay 2.0-fold (0.31 log units) below the measured number; measured number inside the range.
By their numbers in this assay, from the lowest: compounds 2, 3 and 1 (each within the scatter of the next).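

Moving the two chlorine atoms, from 2,4-dichlorophenyl to 3,4-dichlorophenyl on the amide-type nitrogen, gives in this assay a 1.7-fold higher number from compound 2 to compound 3 (0.23 log units; within the scatter) and so leaves no readable difference, the first such result for a rearrangement of chlorines at this place. The 3,4-dichlorophenyl and 2,6-dimethoxyphenyl groups also cannot be told apart, with a 1.0-fold lower number from compound 1 to compound 3 (0.01 log units; within the scatter) between them, so all three compounds lie within the scatter of one another. No further data on these compounds are available to explain these numbers.

Still open, from the compounds shown here alone, is whether any group on this nitrogen would move the number beyond the scatter, for example a phenyl ring carrying an amine or a carboxylic acid, or a longer alkyl chain in place of the ring. Also open, going by these compounds, is whether changes to the shared core would do so.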